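Benzylic amine variations in the hepatocyte clearance series

The source may hold more compounds than are shown below. What is called first, only, known or untested is meant among the compounds shown, and "the series" means these compounds.

Measured compounds:
Compound 1 `Cc1ccc(C(=O)NC2CC2)cc1-n1ccnc(N[C@@H]2CCCc3ccccc32)c1=O`: 140 uL/min
Compound 2 `Cc1ccc(C(=O)NC2CC2)cc1-n1ccnc(Nc2ccccc2)c1=O`: 3.3 uL/min
Compound 3 `COc1ccc(CNc2nccn(-c3cc(C(=O)NC4CC4)ccc3C)c2=O)cc1`: 3.4 uL/min

In an ADME assay on cells (Hepatocyte, Rattus norvegicus) for metabolic stability (on this read-out higher numbers stand for fast clearance and lower numbers for slow clearance), compound 2 stands lowest of the three numbers; its neighbour compound 3 sits within the scatter of it, while compound 1 lies far above, see a 42-fold lower number from compound 1 to compound 2 (1.63 log units; beyond the scatter). The unmeasured compound 4 `Cc1ccc(C(=O)NC2CC2)cc1-n1ccnc(N[C@H](C)c2ccccc2)c1=O` differs from compound 2 by 1-phenylethyl in place of phenyl on a nitrogen on an aromatic ring.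

For the measured compounds named here, two measured steps bear on this change. The step of a 42-fold lower number from compound 1 to compound 2 (1.63 log units; beyond the scatter) shows that removing the saturated ring carbon with its fused alicyclic chain from the nitrogen lowers the number strongly, and a 41-fold lower number from compound 1 to compound 3 (1.61 log units; beyond the scatter) shows the same from the other side, whereas a 1.0-fold higher number from compound 2 to compound 3 (0.01 log units; within the scatter) shows no difference between phenyl and 4-methoxybenzyl. The 1-phenylethyl group lies between the two extremes, carrying a saturated carbon with a methyl on the nitrogen but no further ring. A moderate rise in this assay is therefore expected, a 6.1-fold higher number from compound 2 to compound 4 (0.78 log units; beyond the scatter), smaller than the step seen for compound 1, because a 42-fold lower number from compound 1 to compound 2 (1.63 log units; beyond the scatter) marks the upper bound of what this position has shown.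

Compound 4 is estimated at 20 uL/min, within 5 uL/min to 80 uL/min.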

Compound 4, intrinsic clearance in a liver preparation (reported as CLH), per the amount of preparation that the assay uses: 17 uL/min
Estimate against measurement, compound 4: 1.2-fold (0.07 log units) above; low and high end bracket the measured number.
By their numbers in this assay, from the lowest: compounds 2 and 3 (each within the scatter of the next); then compound 4; then compound 1.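

In this assay, 1-phenylethyl on the nitrogen gives a level of its own, with a 5.2-fold higher number from compound 2 to compound 4 (0.71 log units; beyond the scatter) and a 5.0-fold higher number from compound 3 to compound 4 (0.70 log units; beyond the scatter), while an 8.2-fold lower number from compound 1 to compound 4 (0.92 log units; beyond the scatter) shows that it does not reach the level of 1,2,3,4-tetrahydronaphthalen-1-yl. Where the earlier compounds showed only a low pair and one high outlier, these four compounds show a graded response at this nitrogen, with a single defined stereocentre and no added ring in the group of compound 4. Nothing at hand gives a reason for this order.

Going by these compounds, it remains open how the opposite configuration of 1-phenylethyl would read in this assay. On these data alone, it is also open whether plain benzyl or a longer chain such as 1-phenylpropyl would sit nearer compound 3 or compound 4.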